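The source may hold more compounds than are shown below. What is called first, only, known or untested is meant among the compounds shown, and "the series" means these compounds.

Compound 1 `COC(=O)c1c(C)[n+]([O-])c2cc(Cl)c(Cl)cc2[n+]1[O-]` gives 1.68 ug/mL in an ADME assay on Vero cells (Chlorocebus sabaeus) for cytotoxicity; a lower number here means a stronger inhibitor, a higher number a weaker inhibitor.
Compound 2 `CCc1c(C(=O)OC)[n+]([O-])c2cc(C)ccc2[n+]1[O-]` gives > 62.5 ug/mL in this assay, which is a limit of the assay and not a number.
Compound 3 `CCc1c(C(=O)OC)[n+]([O-])c2cc(Cl)ccc2[n+]1[O-]` gives > 10 ug/mL in this assay, again a limit of the assay rather than a number.

Compound 3 therefore stands on no firm number; of the three values shown, two are limits, as the limit of > 10 ug/mL in this assay, at which 1 of the 3 values shown sits, and the limit of > 62.5 ug/mL in this assay, at which 1 of the 3 values shown sits, record. Among the measured compounds shown here, the only step measured between neighbours is a step that the two limits leave unreadable from compound 2 to compound 3, and the two limits leave its size unreadable.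

Compound 4 `CCc1c(C(=O)OC)[n+]([O-])c2cc(Cl)c(Cl)cc2[n+]1[O-]` arises from compound 3 by a single change: chloro in place of hydrogen on an aromatic carbon. For the measured compounds named here, no measured step carries this exact change, so the expectation rests on what the values show. Going by the values given here, compound 1 also carries two chloro groups on the shared core and sits at a clear number, whereas compound 3 with one chloro group reached only a limit; the two differ as well in methyl against ethyl, and no step between them is recorded.

On that basis compound 4 is expected to move toward stronger cytotoxicity in this assay, with an estimated step of an at least 3.3-fold lower number from compound 3 to compound 4 (0.52 log units; beyond the scatter). The estimate for compound 4 is 3 ug/mL, in a range from 1 ug/mL to 15 ug/mL.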

Compound 4, half-maximal inhibitory concentration: 4 ug/mL
Beside the measured number, compound 4's estimate is 1.3-fold (0.12 log units) below it; the range from low to high includes it.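

Among the compounds shown here, this is the first reading of chloro in place of hydrogen on this aromatic carbon, ortho to a chloro group, and in this assay it gives an at least 2.5-fold lower number from compound 3 to compound 4 (0.39 log units; beyond the scatter). That step has a floor but no readable upper size, because compound 3 holds only a limit: the limit of > 10 ug/mL in this assay, at which 1 of the 4 values shown sits. For the compounds shown here, with both chloro groups kept, methyl in place of hydrogen on a saturated chain carbon bound to an aromatic carbon gives a 2.4-fold higher number from compound 1 to compound 4 (0.38 log units; beyond the scatter), a modest move toward weaker cytotoxicity and the first step in this small set read from one firm number to another.

On these data alone, compound 2 and compound 3 both stand at limits, so the step between them cannot be read, and the effect of chloro in place of methyl on an aromatic carbon stays unknown. As far as these compounds go, it also remains open whether a longer chain, such as propyl, on the saturated carbon would continue the move seen with methyl, and whether an amine on the aromatic carbon that carries the new chloro would give a number near that of compound 4.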